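The compounds below may be only part of what the source reports. "The series", "measured", "known", "first", "only" and "open" are said of these compounds alone.

Measured compounds:
- compound 1, `COc1cc(-c2cc(/C=C/C(=O)c3ccc(N)cc3)[nH]n2)cc(OC)c1OC`: -79%
- compound 2, `COc1ccc(-c2cc(/C=C/C(=O)c3ccc(OC)c(OC)c3)[nH]n2)cc1`: -79%
- compound 3, `COc1cc(-c2cc(/C=C/C(=O)c3ccc(Cl)c(Cl)c3)[nH]n2)cc(OC)c1OC`: 3%

In a functional assay on KM12 cells (Homo sapiens) for cytotoxicity, read by sulforhodamine B assay, with a stated time of 48 h, tested at 100 uM (on this read-out lower numbers stand for a stronger effect and higher numbers for a weaker effect at the one concentration tested), compound 1 gives -79%, level with compound 2 at the digits printed, and together these two are the lowest of the three numbers. For the measured compounds named here, the one measured step that leaves from compound 1 is the exchange of 3,4-dichlorophenyl for 4-aminophenyl on the carbonyl carbon, which gives a number 82 percentage points higher from compound 1 to compound 3 (beyond the scatter), a large move beyond the scatter. Compound 4, `COc1ccc(-c2cc(/C=C/C(=O)c3ccc(N)cc3)[nH]n2)cc1OC`, is not yet measured. It differs from compound 1 by hydrogen in place of methoxy on an aromatic carbon. Going by the values given here, no measured step addresses this particular change: the step to compound 3 alters the ketone end, not the methoxy pattern, and compound 2 carries fewer methoxy groups on that ring but also a different ketone aryl, so only its value can be noted. Since compound 2 sits level with compound 1, a change of methoxy count on that ring does not, on these data, by itself push the read-out up. Compound 4 is therefore expected to stay close to compound 1, with a step of a number 9 percentage points higher from compound 1 to compound 4 (within the scatter) and an estimated value of -70%, within -95% to -30%.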

Compound 4, a percentage reported as activity, at one concentration (the size of the read-out at that concentration, not a potency): -98%
Compound 4: middle estimate off by 28 percentage points, on the high side; measured number outside the range, below it.
By their numbers in this assay, from the lowest: compound 4; then compounds 1 and 2 (each within the scatter of the next); then compound 3.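

In this assay, hydrogen in place of methoxy on the aromatic carbon gives a number 19 percentage points lower from compound 1 to compound 4 (beyond the scatter) and so shows that the read-out responds to a change at this position. For the compounds shown here, the methoxy group at this position is therefore not required for the low read-out, as the number falls further once it is gone, and this is the first one-place step on the methoxy pattern, since the earlier step changed only the ketone end. Nothing measured here explains the direction of this step.

The compounds shown leave open whether a hydroxyl, fluorine or ethoxy group at this position would give a read-out nearer to that of the methoxy or of the hydrogen. They also leave open whether the same exchange would move the read-out in the same direction with a 3,4-dichlorophenyl group at the ketone end.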